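Swapping the amine substituent on a sulfonyl quinoxaline-like core

This account rests on a few compounds, and the source may have more. Where it says the series, first, only, none or still open, it means among the compounds named here.

In a functional assay on PC-3 cells (Homo sapiens) for cytotoxicity, read by MTT assay, with a stated time of 72 h (a higher number here means a weaker inhibitor, a lower number a stronger inhibitor), compound 2 `Nc1cccc(Nc2nc3ccccc3nc2S(=O)(=O)c2ccc(Br)cc2)c1` gives 9010 nM, the higher of the two numbers seen so far, while compound 1 `O=S(=O)(c1ccccc1)c1nc2ccccc2nc1Nc1ccc(C(F)(F)F)cc1` gives 3550 nM, which lies beyond the usual scatter from it. Compound 3 `O=S(=O)(c1ccc(Br)cc1)c1nc2ccccc2nc1Nc1ccc(C(F)(F)F)cc1` has not yet been measured. It differs from compound 2 by 4-(trifluoromethyl)phenyl in place of 3-aminophenyl on a nitrogen on an aromatic ring, in words: 4-(trifluoromethyl)phenyl in place of 3-aminophenyl on a nitrogen on an aromatic ring. Compound 1 already carries this entering group and gives 3550 nM, so compound 3 is expected to show a step of a 2.4-fold lower number from compound 2 to compound 3 (0.37 log units; beyond the scatter), a moderate drop in number. Compound 3 is therefore estimated at 3800 nM, within a range of 1500 nM to 9500 nM in this assay.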

Compound 3, half-maximal inhibitory concentration: 4150 nM
Compound 3: the middle estimate sits 1.1-fold (0.04 log units) below what was measured, within the range that was stated.
By their numbers in this assay, from the lowest: compounds 1 and 3 (each within the scatter of the next); then compound 2.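

In this assay, the change on the nitrogen can now be read with the bromo kept in place: 4-(trifluoromethyl)phenyl in place of 3-aminophenyl gives a 2.2-fold lower number from compound 2 to compound 3 (0.34 log units; beyond the scatter) on its own. Bromo in place of hydrogen on an aromatic carbon gives a 1.2-fold higher number from compound 1 to compound 3 (0.07 log units; within the scatter), so this second change shows no clear effect on the number. Nothing here explains either step. Still open, on these data alone, is how a group such as methoxy or a carboxylic acid would read on that phenyl ring, in place of trifluoromethyl. Also open, as far as these compounds go, is whether 3-aminophenyl gives the same number without the bromo.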